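The compounds below may be only part of what the source reports. "The series", "measured", "known", "first", "only" and "open" are said of these compounds alone.

Working notes on the series. In a functional assay on A20 cells (Mus musculus) for inhibition, with stated times of 1 h, 16 h and 24 h (a lower number here means a stronger inhibitor, a higher number a weaker inhibitor), compound 1 (`CC(C)(C#N)NC(=O)[C@@H]1C[C@@H](S(=O)(=O)c2ccccc2)C[C@H]1C(=O)N1CCOCC1`) gives 43 nM and compound 2 (`CC1CCN(C(=O)[C@@H]2C[C@H](S(=O)(=O)c3ccccc3)C[C@H]2C(=O)NC2(C#N)CC2)CC1`) gives 2 nM. Compound 2 therefore holds the lower of the two numbers, and its gap to compound 1 lies beyond the scatter. Among the measured compounds shown here, no measured pair differs in one place only, so the next step has no direct precedent.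

The next compound is compound 3 (`N#CC1(NC(=O)[C@@H]2C[C@@H](S(=O)(=O)c3ccccc3)C[C@H]2C(=O)N2CC(O)C2)CC1`), with 3-hydroxyazetidin-1-yl in place of 4-methylpiperidin-1-yl on a carbonyl carbon. In this assay, a rise beyond the scatter is expected, meaning a weaker inhibitor than compound 2. For the measured compounds named here, the expected size is guided by compound 1 at 43 nM, the only other number available, and it remains uncertain because the entering group has not yet been measured. The expected change is a 13-fold higher number from compound 2 to compound 3 (1.10 log units; beyond the scatter). For compound 3 the estimated value is 25 nM, with an expected range from 6 nM to 100 nM.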

Compound 3, half-maximal inhibitory concentration: 572 nM
Compound 3: middle estimate off by 23-fold (1.36 log units), on the low side; the whole stated range lies below it.
By their numbers in this assay, from the lowest: compound 2; then compound 1; then compound 3.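

Working notes, continued. In this assay, among the compounds shown here, the group on the carbonyl carbon has a large influence on the read-out: replacing 4-methylpiperidin-1-yl with 3-hydroxyazetidin-1-yl gives a 290-fold higher number from compound 2 to compound 3 (2.46 log units; beyond the scatter), and this is the first step that isolates this position, with the rest of the structure held constant. The exchange alters several counted features at once, going from a six-membered to a four-membered ring, from 7 to 5 heavy atoms, and from no hydrogen-bond donor or acceptor to one of each, and together these changes are clearly not tolerated at this position in this assay. For the compounds shown here, nothing measured so far explains the size of the step.

The compounds shown leave open whether the step follows the smaller ring, the hydroxy group or the loss of the methyl group, since all of these change together; an unsubstituted azetidin-1-yl or a 4-hydroxypiperidin-1-yl on the same carbonyl carbon would help to separate them. On these data alone, it also remains open whether a basic amine such as piperazin-1-yl, or a larger unsubstituted ring such as azepan-1-yl, would be accepted at this position.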